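The source may report more compounds than this note shows. Statements on the series, on what has been measured and on what is new or still open speak of the compounds shown alone.

Measured compounds:
compound 1 `COc1ccc(/C=C/C[C@@H]2C[C@H]([C@H](O)c3ccc(OC)c(OC)c3)CO[C@H]2c2ccc(OC)c(OC)c2)cc1OC` gives 28700 nM in a functional assay on HeLa cells (Homo sapiens) for cytotoxicity, read by WST assay, with a stated time of 48 h; on this read-out lower numbers stand for stronger inhibition and higher numbers for weaker inhibition
compound 2 `C=CC[C@H]1C[C@@H]([C@@H](O)c2ccccc2)CO[C@@H]1c1ccccc1` gives 25400 nM in this assay

Going by the values given here, only two compounds have numbers in this assay. Compound 1 and compound 2 lie within the usual scatter of each other, so neither can be placed above or below the other; compound 1 simply sits alongside compound 2 at the weak end of what these two measurements show. Among the compounds with values here, no pair of measured compounds differing in a single place is available, so there is no measured step to lean on.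

Compound 3 `COc1ccc(/C=C/C[C@H]2C[C@@H]([C@@H](O)c3ccc(OC)c(OC)c3)CO[C@@H]2c2ccc(OC)c(OC)c2)cc1OC` has not yet been measured in this assay. Compared with compound 1, (the two compounds have the same atoms and bonds and differ only in configuration as drawn: 4 of 5 stereo elements differ; a stereocentre at a saturated ring carbon is drawn R in compound 1 and S in compound 3; a stereocentre at a saturated ring carbon is drawn S in compound 1 and R in compound 3; a stereocentre at a saturated chain carbon is drawn S in compound 1 and R in compound 3; a stereocentre at a saturated ring carbon is drawn R in compound 1 and S in compound 3). The change thus concerns configuration only.

With nothing measured about how configuration matters here, compound 3 is expected to give a value close to that of compound 1, and the expected step of a 1.0-fold higher number from compound 1 to compound 3 (0.02 log units; within the scatter) is one that stays within the scatter. Compound 3 is therefore estimated at 30000 nM in this assay, with a range from 10000 nM to 90000 nM.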

Compound 3, half-maximal inhibitory concentration: 23800 nM
Compound 3: the middle estimate sits 1.3-fold (0.10 log units) above what was measured, and the stated range covers the measured number.
By their numbers in this assay, from the lowest: compounds 3, 2 and 1 (each within the scatter of the next).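

In this assay, going by these compounds alone, this pair gives the first comparison in which only one kind of change is in play, which compounds 1 and 2 could not offer: reversing four of the five stereo elements, at three saturated ring carbons and one saturated chain carbon, gives a 1.2-fold lower number from compound 1 to compound 3 (0.08 log units; within the scatter). The step stays within the scatter, so the configuration as drawn at these four stereocentres, changed together, does not separate the two compounds in this read-out. The comparison can be read as one of configuration alone, with no group entering or leaving: the fact that compounds 1 and 3 differ only in the configuration as drawn.

The compounds shown leave open whether any one of the four stereocentres would matter if changed on its own, as all four change together here, and whether configuration would count in a compound with a much lower number in this assay. They also leave open what a different group on the shared core, such as an amine or a carboxylic acid, would do to the number.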